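A Hydroxypentyl Amide Between Two Measured Neighbours

The compounds below may be only part of what the source reports. "The series", "measured", "known", "first", "only" and "open" are said of these compounds alone.

Two compounds with the same core are measured in an assay on CHO cells for displacement of a labelled ligand from adenosine receptor A1 (Homo sapiens), read by scintillation counting, with a stated time of 60 min, tested at 10 uM; a higher number here means more inhibition at the concentration tested (going by the name of the read-out), a lower number less inhibition. Compound 1 `COc1cccc2cc(C(=O)NC3CCCC3)c(=N)oc12` carries a cyclopentyl group on the amide nitrogen. For compound 1 this assay gives only a limit, > 70%. Compound 2 `COc1cccc2cc(C(=O)NC(CO)(CO)CO)c(=N)oc12` carries instead a 2-hydroxy-1,1-bis(hydroxymethyl)ethyl group, and in this assay compound 2 gives 19%. Among the measured compounds shown here, the step of a number at least 51 percentage points lower from compound 1 to compound 2 (beyond the scatter) is the sole measured comparison; its exact size is open because of the limit of > 70% in this assay, at which 1 of the 2 values shown sits. The unmeasured compound 3 `COc1cccc2cc(C(=O)NCCCCCO)c(=N)oc12` differs from compound 2 in one place: 5-hydroxypentyl in place of 2-hydroxy-1,1-bis(hydroxymethyl)ethyl on an amide-type nitrogen. For the measured compounds named here, the one measured step points the way: exchanging cyclopentyl for the 2-hydroxy-1,1-bis(hydroxymethyl)ethyl group cost a large amount of inhibition, and compound 3 moves part of the way back, keeping a hydroxyl on a chain without a ring. A moderate rise beyond the scatter is therefore expected, though smaller than the measured loss. Compound 3 is estimated to give 45%, with a range from 22% to 70%. This estimate means an expected step of a number 26 percentage points higher from compound 2 to compound 3 (beyond the scatter).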

Compound 3, a percentage reported as inhibition, at one concentration (the size of the read-out at that concentration, not a potency): 44%
Compound 3: middle estimate off by 1 percentage points, on the high side; measured number inside the range.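

In this assay the exchange of 2-hydroxy-1,1-bis(hydroxymethyl)ethyl for 5-hydroxypentyl on the amide-type nitrogen gives a number 25 percentage points higher from compound 2 to compound 3 (beyond the scatter) and shows that a hydroxyl-bearing group without a ring at this position need not sit as low as compound 2 does. Even so, the cyclopentyl group keeps its lead, with a number at least 26 percentage points lower from compound 1 to compound 3 (beyond the scatter) as the step, so the 5-hydroxypentyl group recovers only part of the inhibition lost in compound 2. The full size of that remaining gap cannot be given because compound 1 is reported only as a limit: the limit of > 70% in this assay, at which 1 of the 3 values shown sits.

This step changes two things at once: 3 hydrogen-bond donors become 1 hydrogen-bond donor, and the group's carbon skeleton changes too, so the compounds shown cannot say which of these matters for the read-out. Also open, on these data alone, is how a plain pentyl chain with no hydroxyl, or a five-carbon chain ending in an amine or a carboxylic acid, would behave on this same nitrogen, and whether either would come closer to compound 1.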